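The source may report more compounds than this note shows. Statements on the series, on what has been measured and on what is new or still open speak of the compounds shown alone.

Measured so far:
Compound 1 `CCOC(=O)c1cccc(-c2ccc(OCC)cc2)c1`: in an assay on COS-7 cells for inhibition of patatin-like phospholipase domain-containing protein 2 (Mus musculus), tested at 200 uM (on this read-out higher numbers stand for more inhibition at the one concentration tested (going by the name of the read-out) and lower numbers for less inhibition), compound 1 gives 87%.
Compound 2 `CCOc1ccc(-c2cccc(C(=O)OCCOC)c2)cc1`: in this assay compound 2 gives 89%.

Compound 2 holds the highest of the two numbers, with compound 1 nearest; the step of a number 2 percentage points higher from compound 1 to compound 2 (within the scatter) lies within the scatter, so the two cannot be ranked. Compound 3 `CCOc1ccc(-c2cccc(NC(=O)N(C)C)c2)cc1` remains to be measured. It differs from compound 2 in one place: (dimethylcarbamoyl)amino in place of (2-methoxyethoxy)carbonyl on an aromatic carbon. For the measured compounds named here, the only measured step, a number 2 percentage points higher from compound 1 to compound 2 (within the scatter), concerns a change on the chain of the (2-methoxyethoxy)carbonyl group and says nothing about exchanging that group for (dimethylcarbamoyl)amino, so no measured step bears on this change. Both measured compounds carry the (2-methoxyethoxy)carbonyl group and give high inhibition; for compound 3 a fall beyond the scatter is expected, since the group that held across both is removed, amounting to the step of a number 34 percentage points lower from compound 2 to compound 3 (beyond the scatter). Compound 3 is therefore expected to give 55% in this assay, within a range of 15% to 90%.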

Compound 3, a percentage reported as inhibition, at one concentration (the size of the read-out at that concentration, not a potency): 68%
For compound 3 the middle estimate is 13 percentage points below the measured one; low and high end bracket the measured number.
By their numbers in this assay, from the lowest: compound 3; then compounds 1 and 2 (each within the scatter of the next).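

In this assay, the earlier pair showed only a change on the chain of the ester, whereas here the whole group on the aromatic carbon is exchanged and the read-out responds: (dimethylcarbamoyl)amino gives a number 21 percentage points lower from compound 2 to compound 3 (beyond the scatter) and, set against ethoxycarbonyl, a number 19 percentage points lower from compound 1 to compound 3 (beyond the scatter). Both steps are modest, so inhibition at the one concentration tested falls but is not lost when this place carries no ester. No measurement bears on why the exchange lowers the number.

The compounds shown leave open whether the fall belongs to the nitrogen attached to the aromatic carbon or to the dimethylamide end of the entering group. A carboxylic acid or a simple amine on the same aromatic carbon would test how far inhibition depends on the group at this place.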